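The source may hold more compounds than are shown below. What is called first, only, known or untested is meant among the compounds shown, and "the series" means these compounds.

Series notes, hydroxamic acid chain with a varied cap and amide end.

Two compounds have numbers in a functional assay on NFF cells (Homo sapiens) for antiproliferative activity; a lower number here means a stronger inhibitor, a higher number a weaker inhibitor. Compound 1 `O=C(CCCCC[C@H](NC(=O)OCc1ccccc1)C(=O)NCc1ccncc1)NO` gives 23300 nM. Compound 2 `CN(C)c1ccc(C(=O)N[C@@H](CCCCCC(=O)NO)C(=O)Nc2cccc3cccnc23)cc1` gives 570 nM and so stands with the lowest of the two numbers; compound 1 sits at a higher number, a gap beyond the scatter. Compound 1 and compound 2 differ in two places at once, so the two values alone cannot be split between the cap and the amide end.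

Compound 3 `O=C(CCCCC[C@H](NC(=O)OCc1ccccc1)C(=O)Nc1cccc2cccnc12)NO` is not yet measured. Against compound 2 the change is benzyloxy in place of 4-(dimethylamino)phenyl on a carbonyl carbon, the cap on the carbonyl carbon next to the amide-type nitrogen; the amide end of compound 2 is kept. Going by the values given here, the benzyloxy group is the one carried by compound 1, whose value 23300 nM is the higher of the two known.

In this assay compound 3 is expected to give 2500 nM, with a range of 600 nM to 10000 nM. The step of a 4.4-fold higher number from compound 2 to compound 3 (0.64 log units; beyond the scatter) is expected to run toward a higher number, beyond the scatter but well short of the distance between compound 1 and compound 2.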

Compound 3, half-maximal inhibitory concentration: 452 nM
Compound 3: middle estimate off by 5.5-fold (0.74 log units), on the high side, and the stated range ends above it.
By their numbers in this assay, from the lowest: compounds 3 and 2 (each within the scatter of the next); then compound 1.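

In this assay, benzyloxy in place of 4-(dimethylamino)phenyl on a carbonyl carbon, with the quinolin-8-yl amide end kept, gives a 1.3-fold lower number from compound 2 to compound 3 (0.10 log units; within the scatter), so these two caps are not told apart at this position. With the benzyloxy cap kept, quinolin-8-yl in place of (pyridin-4-yl)methyl on an amide-type nitrogen gives a 52-fold lower number from compound 1 to compound 3 (1.71 log units; beyond the scatter), a large step that now belongs to the amide end alone, whereas the two-place difference between compound 1 and compound 2 could not be divided. No measurement at hand accounts for either step.

Going by these compounds, both readings rest on a single pair each, so it remains open whether the two caps would also stay within the scatter of each other on the (pyridin-4-yl)methyl amide end, and whether the step at the amide end would keep its size with the 4-(dimethylamino)phenyl cap. Also open, on these data alone, is how this assay would respond to a plain phenyl or benzyl group on the amide-type nitrogen, to an amine or a carboxylic acid in the cap, or to a longer chain carrying the hydroxamic acid.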